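Swapping Chloro for Nitro on a Sulfonyl-Bearing Aromatic Ring

This account rests on a few compounds, and the source may have more. Where it says the series, first, only, none or still open, it means among the compounds named here.

Going by the values given here, compound 2 `O=C1C=CC2(C=C1)OCC(=O)N2S(=O)(=O)c1ccc(Cl)cc1` holds the only true number in this pair, with compound 2 at 860 nM in a functional assay on HepG2 cells (Homo sapiens) for inhibition, read by sulforhodamine B assay, with a stated time of 74 h; on this read-out higher numbers stand for weaker inhibition and lower numbers for stronger inhibition. Compound 1 `Cc1ccc(S(=O)(=O)N2C(=O)COC23C=CC(=O)C=C3)cc1` gives > 10000 nM in this assay, and this is a limit of the assay, not a number. Among the compounds with values here, the one measured step is an at least 11-fold lower number from compound 1 to compound 2 (1.06 log units; beyond the scatter), with chloro in place of methyl on an aromatic carbon. Compound 3 `O=C1C=CC2(C=C1)OCC(=O)N2S(=O)(=O)c1ccc([N+](=O)[O-])cc1` keeps the shared core and changes that same group again: nitro in place of chloro on an aromatic carbon. So chloro leaves and nitro enters, para to a large group. Within the data shown here, only the step from compound 1 to compound 2 bears on this change. It shows that the group can move the number strongly, but it has a limit at one end and does not involve nitro. A modest step towards a lower number in this assay is therefore expected, much smaller than the measured one and close to the edge of the scatter. That expectation amounts to an estimated 2.2-fold lower number from compound 2 to compound 3 (0.33 log units; beyond the scatter). Compound 3 is expected at about 400 nM, with an estimated range from 120 nM to 1500 nM.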

Compound 3, half-maximal inhibitory concentration: > 10000 nM
Compound 3: no number, only a limit; the forecaster's own chance of this, stated with the estimate: 5%; middle value at least 25-fold (1.39 log units) from the limit.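

In this assay, nitro in place of chloro on the aromatic carbon para to a large group gives an at least 11-fold higher number from compound 2 to compound 3 (1.06 log units; beyond the scatter). The earlier step showed only that chloro gave a lower number than methyl at this position. Going by these compounds alone, this result shows that a second replacement at the same carbon can lose that gain again, leaving chloro as the only one of the three groups here that gives a true number. Compound 1 and compound 3 both stop at a limit of the assay rather than at a number, so the step between them cannot be read: the limit of > 10000 nM in this assay, at which 2 of the 3 values shown sit.

From the compounds shown here alone, how far past that limit compound 1 and compound 3 would lie remains open, so the full size of the gap to compound 2 is unknown, and nothing separates methyl from nitro. Also open, going by these compounds, is how an amine, a methoxy group, a fluorine atom or a bromine atom on this same carbon would read against the chloro of compound 2, since three groups alone cannot show what sets the number at this position.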